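The compounds below may be only part of what the source reports. "The series", "measured", "known", "first", "only" and "open" are said of these compounds alone.

Compound 1, `CNCc1cn(S(=O)(=O)c2cccs2)c(-c2cccnc2F)c1F`, is the starting point. Within the data shown here, in a physicochemical assay for lipophilicity, read by HPLC, at pH 7.4 (on this read-out lower numbers stand for lower lipophilicity and higher numbers for higher lipophilicity), compound 1 gives 0.54, the highest of the three values measured so far. Compound 2, `CNCc1cn(S(=O)(=O)c2ccco2)c(-c2cccnc2F)c1F`, gives 0.2 in this assay, and compound 3, `CNCc1cn(S(=O)(=O)c2ncccc2C)c(-c2cccnc2F)c1F`, gives 0.32. Both steps away from compound 1 run downward: a number 0.34 log units lower from compound 1 to compound 2 (beyond the scatter), and a number 0.22 log units lower from compound 1 to compound 3 (within the scatter). Between the two lower compounds, a number 0.12 log units higher from compound 2 to compound 3 (within the scatter).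

Compound 4, `CNCc1cn(S(=O)(=O)c2cccnc2C)c(-c2cccnc2F)c1F`, has not yet been measured in this assay. It differs from compound 1 in a single place: 2-methylpyridin-3-yl in place of thiophen-2-yl on a sulfonyl sulfur. Among the measured compounds shown here, the closest precedent is the step from compound 1 to compound 3, which also places a methyl-substituted pyridinyl, there 3-methylpyridin-2-yl, on the sulfonyl sulfur, and that step stayed within the scatter. The change to furan-2-yl in compound 2 gave a somewhat larger drop. A small downward step, or none beyond the scatter, is therefore expected, a number 0.29 log units lower from compound 1 to compound 4 (within the scatter). Compound 4 is estimated to give 0.25 in this assay, with the expected range running from 0 to 0.5.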

Compound 4, distribution coefficient: 0.48
Compound 4: middle estimate off by 0.23 log units, on the low side; measured number inside the range.
By their numbers in this assay, from the lowest: compounds 2, 3, 4 and 1 (each within the scatter of the next, the first and the last beyond it).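

In this assay, putting the six-membered 2-methylpyridin-3-yl on the sulfonyl sulfur in place of the five-membered thiophen-2-yl leaves the number within the scatter (a number 0.06 log units lower from compound 1 to compound 4 (within the scatter)). The two methylpyridinyl groups, 3-methylpyridin-2-yl and 2-methylpyridin-3-yl, cannot be told apart at this position (a number 0.16 log units higher from compound 3 to compound 4 (within the scatter)), so this read-out does not separate these two arrangements of the same ring and methyl group. Compound 4 also stays within the scatter of the furan-2-yl compound (a number 0.28 log units higher from compound 2 to compound 4 (within the scatter)), although the printed step between compound 1 and compound 2 lies beyond it, so compound 4 cannot be assigned to either end of the series.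

No measurement here explains why these numbers lie so close together. As far as these compounds go, whether a cyclohexyl group, or a pyridine ring carrying an amine or a carboxylic acid, on the sulfonyl sulfur would stay in this narrow band remains open.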